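The compounds below may be only part of what the source reports. "The series", "measured", "known", "first", "only" and "open" are said of these compounds alone.

Measured compounds:
compound 1, `C/N=C(\S)NCCCCn1nc(C)ccc1=O`, 44.5%
compound 2, `C/N=C(/NC#N)NCCCCn1nc(N(C)C)ccc1=O`, 26.3%
compound 3, `CN(C)/C(=N/CCCCn1nc(-c2ccccc2)ccc1=O)NC#N`, 80.7%

Of the compounds shown here, three have been tested in a functional assay on the whole organism with Rattus norvegicus as the target, at a dose of 100 mg/kg; a higher number here means more inhibition at the dose given (going by the name of the read-out), a lower number less inhibition. Compound 1, with the structure `C/N=C(\S)NCCCCn1nc(C)ccc1=O`, gives 44.5% in this assay. Compound 2, `C/N=C(/NC#N)NCCCCn1nc(N(C)C)ccc1=O`, gives 26.3%. Compound 3, `CN(C)/C(=N/CCCCn1nc(-c2ccccc2)ccc1=O)NC#N`, gives 80.7%, the highest of the three numbers; its nearest neighbour is compound 1, whose number is lower by a margin beyond the scatter, and compound 2 lies further below it, also beyond the scatter.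

The account now turns from compound 3 to compound 4, `C/N=C(/NC#N)NCCCCCn1nc(-c2ccccc2)ccc1=O`, which has not yet been measured in this assay. The two compounds contain the same atoms joined differently, and the change is a group of 8 heavy atoms (4 carbon, 4 nitrogen; no ring) in place of a group of 8 heavy atoms (4 carbon, 4 nitrogen; no ring), on a saturated chain carbon, four bonds along the chain from an aromatic nitrogen.

Among the measured compounds shown here, no pair of measured compounds differs in a single place, so there is no measured step to lean on for this change. Compound 2, which carries a cyanoguanidine with a methyl on one nitrogen, gives a lower number than compound 3, but it differs at the core as well, so that comparison only shows what the two values are. The step of a number 25.7 percentage points lower from compound 3 to compound 4 (beyond the scatter) is therefore expected to be a moderate fall, with wide uncertainty. Compound 4 is estimated at 55%, within a range from 25% to 85%.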

Compound 4, a percentage reported as inhibition, in the whole organism at one dose (the size of the read-out at that dose, not a potency): 47.6%
Compound 4: the middle estimate sits 7.4 percentage points above what was measured; measured number inside the range.
By their numbers in this assay, from the lowest: compound 2; then compounds 1 and 4 (each within the scatter of the next); then compound 3.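

In this assay, among the compounds shown here, the exchange on a saturated chain carbon, four bonds along the chain from an aromatic nitrogen, produces a number 33.1 percentage points lower from compound 3 to compound 4 (beyond the scatter) and is the first step in this set that can be read at a single place, so it shows that the read-out at this dose responds to how this part of the molecule is joined. The group that leaves and the group that enters both hold 8 heavy atoms (4 carbon, 4 nitrogen) and no ring, and what is counted differently is the hydrogen-bond donors, 1 in the group that leaves and 2 in the group that enters, so a large fall here comes with no change in the atoms present. Nothing measured here accounts for that fall.

The one step moves several atoms at once, and the compounds shown do not tell which part of the rearrangement carries it. On these data alone, what a primary amine or a carboxylic acid at this place would give in this assay also stays open, as does the outcome for a hexyl chain carrying the same end group.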